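The source may hold more compounds than are shown below. What is called first, only, known or untested is meant among the compounds shown, and "the series" means these compounds.

Compound 1 `COc1cc2ccc(=O)oc2cc1OC(=O)c1c(C)noc1-c1ccccc1F` and compound 2 `COc1cc2ccc(=O)oc2cc1OC(=O)c1c(C)noc1-c1ccccc1` share one core and differ in a single place: hydrogen in place of fluoro on an aromatic carbon. In a functional assay on SW-620 cells (Homo sapiens) for inhibition, read by MTT assay, with a stated time of 48 h (on this read-out higher numbers stand for weaker inhibition and lower numbers for stronger inhibition), compound 1 reaches only a limit of the assay, > 25000 nM. In this assay compound 2 gives 23400 nM. The step of an at least 1.0-fold lower number from compound 1 to compound 2 (0.02 log units; that floor lies within the scatter) is therefore small, and the limit in question is the limit of > 25000 nM in this assay, at which 2 of the 3 values shown sit.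

Compound 3 `COc1cc2ccc(=O)oc2cc1OC(=O)c1c(-c2ccccc2F)n[nH]c1C` has a different core; how it differs from compound 1 is not broken down here. In this assay compound 3 also reaches only a limit, > 25000 nM.

Compound 4 `COc1cc2ccc(=O)oc2cc1OC(=O)c1c(-c2ccccc2)n[nH]c1C` differs from compound 3 by hydrogen in place of fluoro on an aromatic carbon, the same change as that between compound 1 and compound 2. Because that earlier step an at least 1.0-fold lower number from compound 1 to compound 2 (0.02 log units; that floor lies within the scatter) stayed within the scatter, compound 4 is expected to show a step of about a number no higher from compound 3 to compound 4 (the limit leaves the size open). Compound 4 is estimated at 25000 nM, expected between 12000 nM and 50000 nM.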

Compound 4, half-maximal inhibitory concentration: > 25000 nM
Compound 4 was reported as a limit (the forecaster's own chance of this, stated with the estimate: 60%); the middle value lies on the limit itself.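

Among these compounds, compound 3 and compound 4 both reach only a limit of the assay, so no step between them can be read: the limit of > 25000 nM in this assay, at which 3 of the 4 values shown sit.

The compounds shown leave open how strongly either compound inhibits, and whether going from 2-fluorophenyl to phenyl changes anything on this core.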